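The compounds below may be only part of what the source reports. "The series", "measured", "known", "first", "only" and "open" are said of these compounds alone.

Measured so far:

Compound 1 `Cc1ccccc1C#Cc1ccc2c(n1)CCN(C(C)C)C2=O`: 810 nM
Compound 2 `CC(C)N1CCc2nc(C#Cc3ccccc3Cl)ccc2C1=O`: 2520 nM

Compound 2 stands at the higher of the two numbers in a functional assay on HEK293 cells for negative allosteric modulation of metabotropic glutamate receptor 5 (Homo sapiens), read by FLIPR and calcium flux; on this read-out lower numbers stand for stronger inhibition and higher numbers for weaker inhibition; compound 1 sits at the lower one, and the step of a 3.1-fold higher number from compound 1 to compound 2 (0.49 log units; beyond the scatter) is beyond the scatter. Compound 3 `CC(C)N1CCc2nc(C#Cc3cccc(Cl)c3)ccc2C1=O` is not yet measured; it differs from compound 2 only by 3-chlorophenyl in place of 2-chlorophenyl on a triple-bonded carbon. Among the compounds with values here, no measured step bears directly on this change: the one step known, a 3.1-fold higher number from compound 1 to compound 2 (0.49 log units; beyond the scatter), swaps the group itself rather than where it sits, so it tells nothing about moving the chlorine on the ring. What compound 2 shows in this assay is therefore the only anchor. The account expects compound 3 to stay in the same region, with the step of a 1.7-fold lower number from compound 2 to compound 3 (0.23 log units; within the scatter) taken as no more than modest and its direction uncertain. The estimate for compound 3 is 1500 nM, within 400 nM to 6000 nM.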

Compound 3, half-maximal inhibitory concentration: 5.7 nM
Beside the measured number, compound 3's estimate is 260-fold (2.42 log units) above it; measured number outside the range, below it.
By their numbers in this assay, from the lowest: compound 3; then compound 1; then compound 2.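

In this assay, moving the chlorine within the ring, with the atoms otherwise unchanged, gives a 440-fold lower number from compound 2 to compound 3 (2.65 log units; beyond the scatter), so the placement of this one atom counts for far more than the earlier swap of methyl for chloro suggested. The 3-chlorophenyl group also stands well clear of 2-methylphenyl on the same triple-bonded carbon, with a 140-fold lower number from compound 1 to compound 3 (2.15 log units; beyond the scatter), so this position tolerates very different outcomes across small changes in the ring. Nothing available explains why the two chlorophenyl groups part so sharply.

From the compounds shown here alone, what 3-methylphenyl or 3-methoxyphenyl would give on this triple-bonded carbon remains open, so the result cannot yet be tied to chlorine itself. Going by these compounds, it is also open whether 3-chlorophenyl would keep its advantage if a cyclopropyl group replaced the isopropyl group on the shared core.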